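Methylating the Amide Nitrogen of Compound 2

A few compounds are considered here, and "the series" means these few. Any claim that something is new, unique, unknown or untested is made for them only; others in the source may bear on it.

Compound 2 `CC(C)c1c(C(=O)NCc2ccccc2)nn(-c2ccc(F)cc2)c1OC[C@@H](O)C[C@@H](O)CC(=O)O` is the reference point. Within the data shown here, in an assay on microsomes from liver for inhibition of 3-hydroxy-3-methylglutaryl-coenzyme A reductase (Rattus norvegicus) (on this read-out higher numbers stand for weaker inhibition and lower numbers for stronger inhibition), compound 2 gives 3.8 nM, the lowest of the three numbers measured so far. Compound 1 `CC(C)c1c(C(=O)N(C)Cc2cccc(F)c2)nn(-c2ccc(F)cc2)c1CC[C@@H](O)C[C@@H](O)CC(=O)O`, which carries a different linker and a methylated amide bearing a fluorinated benzyl group, gives 4.1 nM in this assay; that number lies within the scatter of compound 2, so the two cannot be ranked. Compound 3 `CC(C)c1c(C(=O)NCC2CCCCC2)nn(-c2ccc(F)cc2)c1OC[C@@H](O)C[C@@H](O)CC(=O)O` gives 17 nM, and the step of a 4.5-fold higher number from compound 2 to compound 3 (0.65 log units; beyond the scatter) shows that cyclohexyl in place of phenyl weakens inhibition modestly.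

Compound 4 `Cc1ccc(CN(C)C(=O)c2nn(-c3ccc(F)cc3)c(OC[C@@H](O)C[C@@H](O)CC(=O)O)c2C(C)C)cc1` differs from compound 2 in one place: methyl(4-methylbenzyl)amino in place of benzylamino on a carbonyl carbon. The aromatic ring is kept, so the weakening seen with cyclohexyl does not apply. Among the measured compounds shown here, no measured step isolates methylation of the amide nitrogen or the added methyl on the ring; the value of compound 1 shows only that a methylated amide can sit alongside strong inhibition. Compound 4 is therefore expected to give about 5 nM, with a range from 2 nM to 15 nM. The expected step of a 1.3-fold higher number from compound 2 to compound 4 (0.12 log units; within the scatter) is small.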

Compound 4, half-maximal inhibitory concentration: 37 nM
Estimate against measurement, compound 4: 7.4-fold (0.87 log units) below; the whole stated range lies below it.
By their numbers in this assay, from the lowest: compounds 2 and 1 (each within the scatter of the next); then compound 3; then compound 4.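

Keeping an aromatic ring on this carbonyl carbon does not by itself preserve inhibition: in this assay, methyl(4-methylbenzyl)amino in place of benzylamino gives a 9.7-fold higher number from compound 2 to compound 4 (0.99 log units; beyond the scatter). The new group also falls behind the saturated (cyclohexylmethyl)amino group, with a 2.2-fold higher number from compound 3 to compound 4 (0.34 log units; beyond the scatter), so compound 4 goes against the ordering of compound 2 over compound 3, in which the aromatic ring gave the stronger inhibition. Nothing available explains why this change weakens inhibition.

From the compounds shown here alone, the change removes the amide hydrogen and adds a methyl on the ring together, so the share of each remains open. Methyl(benzyl)amino and 4-methylbenzylamino would each carry only one of these two changes, and a longer chain, as in phenethylamino, remains an open question at this position.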